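The compounds below may be only part of what the source reports. "The series", "measured", "known", "first", "only" and "open" are said of these compounds alone.

Working notes on the series. Compound 1 `CCc1ccc(C(=O)Nc2cccc(NC(=O)COc3ccc4c(=O)ccoc4c3)c2)cc1` and compound 2 `CC(C)(C)c1ccc(C(=O)Nc2cccc(NC(=O)COc3ccc4c(=O)ccoc4c3)c2)cc1` share the same core and differ only at one aromatic carbon. In an assay on isolated protein for inhibition of Rho-associated protein kinase 2 (Homo sapiens), read by scintillation counting, radiometric assay and 33P incorporation, with a stated time of 40 min, in the presence of a further agent that is not named here (on this read-out higher numbers stand for weaker inhibition and lower numbers for stronger inhibition), compound 1 gives 24 nM, and in the same assay compound 2 gives 34 nM. Among the compounds with values here, compound 2 thus holds the higher of the two numbers so far, but the step of a 1.4-fold higher number from compound 1 to compound 2 (0.15 log units; within the scatter) sits inside the usual scatter, so the two compounds cannot be placed in order against each other.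

Compound 3 `O=C(COc1ccc2c(=O)ccoc2c1)Nc1cccc(NC(=O)c2ccc(F)cc2)c1` is the next member and is not yet measured. Relative to compound 2 the change is fluoro in place of tert-butyl on an aromatic carbon. Within the data shown here, the only measured step that touches this position is a 1.4-fold higher number from compound 1 to compound 2 (0.15 log units; within the scatter), where the group on this aromatic carbon was exchanged without a change beyond the scatter. Among the measured compounds shown here, no measured pair shows a fluoro at this position, so the expectation for compound 3 rests on that single step alone. On that basis the step of a 1.1-fold lower number from compound 2 to compound 3 (0.03 log units; within the scatter) is expected to stay within the scatter, in no definite direction. Compound 3 is therefore estimated at 32 nM, with a plausible range from 12 nM to 90 nM.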

Compound 3, half-maximal inhibitory concentration: 54 nM
For compound 3 the middle estimate is 1.7-fold (0.23 log units) below the measured one; the range from low to high includes it.
By their numbers in this assay, from the lowest: compounds 1, 2 and 3 (each within the scatter of the next, the first and the last beyond it).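

In this assay, the exchange of 4-(tert-butyl)phenyl for 4-fluorophenyl gives a 1.6-fold higher number from compound 2 to compound 3 (0.20 log units; within the scatter), so replacing a group of four heavy atoms with a single fluorine leaves compound 2 and compound 3 unresolved from each other. Within the data shown here, the comparison with ethyl gives a 2.3-fold higher number from compound 1 to compound 3 (0.35 log units; beyond the scatter), the first step at this aromatic carbon to pass beyond the scatter, so the position is not wholly indifferent to its substituent, although the effect is modest and compound 2 stays within the scatter of both neighbours. Since tert-butyl cannot be ordered against either ethyl or fluoro, the three compounds support no trend with group size, and no measurement at hand accounts for the step from ethyl to fluoro.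

The compounds shown leave open how this assay would read with an amine, a carboxylic acid, a methoxy group or a longer alkyl chain on this aromatic carbon. They also leave open whether a chloro group would track with fluoro, and whether the modest step seen with fluoro would hold on the shared core with other groups elsewhere.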